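The source may hold more compounds than are shown below. What is called first, only, known or untested is meant among the compounds shown, and "the series" means these compounds.

Three compounds have been measured in an assay on isolated protein for inhibition of aldehyde dehydrogenase 1A1 (Homo sapiens), read by spectrophotometry, tested at 10 uM; a lower number here means less inhibition, a higher number more inhibition at the concentration tested (going by the name of the read-out):

Compound 1 `Cc1cccc(Cn2c(CN3CCN(C(=O)c4ccc([N+](=O)[O-])cc4)CC3)nc3ccccc32)c1`: 24.3%
Compound 2 `Cc1cccc(Cn2c(CN3CCN(C(=O)c4ccc(C(C)C)cc4)CC3)nc3ccccc32)c1`: 67.6%
Compound 3 `Cc1cccc(Cn2c(CN3CCN(C(=O)c4ccc(C#N)cc4)CC3)nc3ccccc32)c1`: 20.8%

Compound 3 gives the lowest of the three numbers, though its step from compound 1 is small (a number 3.5 percentage points lower from compound 1 to compound 3 (within the scatter)), while compound 2 stands far above it (a number 46.8 percentage points lower from compound 2 to compound 3 (beyond the scatter)). Compound 4 `CCCC(=O)N1CCN(Cc2nc3ccccc3n2Cc2cccc(C)c2)CC1` differs from compound 3 at the amide end: propyl in place of 4-cyanophenyl on a carbonyl carbon. Among the measured compounds shown here, none of the measured steps bears on this directly; each of them swaps one group on the aromatic ring for another, and the largest of them (a number 43.3 percentage points higher from compound 1 to compound 2 (beyond the scatter)) shows only that this end of the molecule can move the read-out widely. The direction of the change to a chain is therefore open. Compound 4 is expected to give about 30%, between 5% and 60%, an estimated step of a number 9.2 percentage points higher from compound 3 to compound 4 (within the scatter).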

Compound 4, a percentage reported as inhibition, at one concentration (the size of the read-out at that concentration, not a potency): 79.1%
Compound 4: middle estimate off by 49.1 percentage points, on the low side; measured number above the stated range.
By their numbers in this assay, from the lowest: compounds 3 and 1 (each within the scatter of the next); then compound 2; then compound 4.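

The ring at this amide end is not needed for inhibition in this assay: propyl on the carbonyl carbon exceeds all three substituted phenyl groups, with a number 58.3 percentage points higher from compound 3 to compound 4 (beyond the scatter), a number 54.8 percentage points higher from compound 1 to compound 4 (beyond the scatter) and a number 11.5 percentage points higher from compound 2 to compound 4 (beyond the scatter). The last step is the smallest, so among these compounds only the 4-isopropylphenyl group comes near propyl. Nothing measured here explains this rise.

Still open, going by these compounds, is how far the chain can change, for instance whether a butyl or hexyl chain, a cyclohexyl ring or an amine on the propyl chain would give a similar number in this assay.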